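Methoxy for Nitro on the Pendant Phenyl Ring

The source may hold more compounds than are shown below. What is called first, only, known or untested is meant among the compounds shown, and "the series" means these compounds.

Measured so far:
- compound 1 `COc1cccc(-c2nc3c(-c4ccc(Cl)cc4)n[nH]c3c(=O)n2NC(=O)c2ccncc2)c1`: 42.5%
- compound 2 `COc1cccc(-c2nc3c(-c4cccc(Cl)c4)n[nH]c3c(=O)n2NC(=O)c2ccccc2)c1`: "not determined" (no result reported)
- compound 3 `O=C(Nn1c(-c2cccc([N+](=O)[O-])c2)nc2c(-c3ccc(Cl)cc3)n[nH]c2c1=O)c1ccccc1`: 86.8%

In a functional assay on SK-OV-3 cells (Homo sapiens) for cytotoxicity, read by sulforhodamine B assay, with a stated time of 2 days, tested at 100 uM (on this read-out higher numbers stand for more inhibition at the one concentration tested (going by the name of the read-out) and lower numbers for less inhibition), compound 3 gives 86.8% and stands highest of the two numbers available. Its nearest neighbour is compound 1, which gives 42.5% in this assay, a gap well beyond the usual scatter. In this assay compound 2 gives "not determined" (no result reported), so it cannot be placed.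

The step to compound 4 `COc1cccc(-c2nc3c(-c4ccc(Cl)cc4)n[nH]c3c(=O)n2NC(=O)c2ccccc2)c1` changes one group on the shared core: methoxy in place of nitro on an aromatic carbon. Within the data shown here, the only other compound carrying a 3-methoxyphenyl with a number, compound 1, sits far below compound 3, though it also differs in its amide part, so that comparison is indirect. In this assay a downward step of moderate size is expected, the change from compound 3 to compound 4 estimated at a number 31.8 percentage points lower from compound 3 to compound 4 (beyond the scatter). Compound 4 is therefore expected to give about 55%, within a range from 30% to 80%.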

Compound 4, a percentage reported as inhibition, at one concentration (the size of the read-out at that concentration, not a potency): 81.7%
Estimate against measurement, compound 4: 26.7 percentage points below, and the stated range ends below it.
By their numbers in this assay, from the lowest: compound 1; then compounds 4 and 3 (each within the scatter of the next).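

In this assay, methoxy and nitro cannot be told apart on this pendant phenyl ring of the shared core, since the swap from 3-nitrophenyl to 3-methoxyphenyl gives a step within the scatter (a number 5.1 percentage points lower from compound 3 to compound 4 (within the scatter)). The low value of compound 1 therefore cannot be pinned on its methoxy group: with 3-methoxyphenyl held in place, phenyl in place of pyridin-4-yl on the carbonyl carbon gives a large step (a number 39.2 percentage points higher from compound 1 to compound 4 (beyond the scatter)). Nothing measured here explains either result.

The compounds shown leave open whether this ring position would accept very different groups, such as an amine or a carboxylic acid, as readily as these two. With a single test concentration, they also leave open whether compound 3 and compound 4 would still match across a range of concentrations.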